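The source may hold more compounds than are shown below. What is called first, only, known or untested is meant among the compounds shown, and "the series" means these compounds.

Measured so far:
compound 1 `O=C1NC(=O)/C(=C/c2ccc(OCCSc3nnc(-c4ccccc4)[nH]3)cc2)S1` — 18.6%
compound 2 `O=C1NC(=O)/C(=C/c2ccc(OCCSc3nnc(Cc4ccccc4)[nH]3)cc2)S1` — 22.5%

In a functional assay on the whole organism (strain Wistar) with Rattus norvegicus as the target, with a stated time of 15 days, at a dose of 3 mg/kg by the oral route (a lower number here means a weaker effect, a higher number a stronger effect of the compound at the dose given), compound 1 gives 18.6%, and compound 2 gives 22.5%. The two numbers sit within the scatter of one another, so the step of a number 3.9 percentage points higher from compound 1 to compound 2 (within the scatter) carries no direction that can be trusted; compound 1 is simply one of two compounds that read alike in this assay, and nothing separates it from compound 2 beyond the noise of the measurement.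

The next compound is compound 3 `COc1ccc(-c2nnc(SCCOc3ccc(/C=C4\SC(=O)NC4=O)cc3)[nH]2)cc1`. It differs from compound 1 by methoxy in place of hydrogen on an aromatic carbon. Among the compounds with values here, the only measured step, a number 3.9 percentage points higher from compound 1 to compound 2 (within the scatter), concerns a different change at the same aromatic carbon, and it stayed within the scatter; no measured pair shows a methoxy entering for hydrogen, so there is no direct precedent. Within the data shown here, with the one step available flat, the expectation for compound 3 is a step of a number 1.4 percentage points higher from compound 1 to compound 3 (within the scatter), that is none beyond the scatter. Compound 3 is therefore estimated at 20%, with a range of 8% to 34%.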

Compound 3, a percentage reported as activity, at one dose (the size of the read-out at that dose, not a potency): 43.1%
Compound 3: middle estimate off by 23.1 percentage points, on the low side; measured number outside the range, above it.
By their numbers in this assay, from the lowest: compounds 1 and 2 (each within the scatter of the next); then compound 3.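

In this assay, within the data shown here, methoxy in place of hydrogen on the six-membered aromatic ring of carbon only, para to a large group, gives a number 24.5 percentage points higher from compound 1 to compound 3 (beyond the scatter), the first step that lies beyond the scatter. The change from benzyl to 4-methoxyphenyl reads the same way, at a number 20.6 percentage points higher from compound 2 to compound 3 (beyond the scatter), so the flat step of a number 3.9 percentage points higher from compound 1 to compound 2 (within the scatter) did not mean that this end of the molecule is indifferent to substitution at the dose given. Nothing at hand bears on the reason for this step.

With a single substituent at a single place on the ring, the compounds shown leave open whether the step belongs to methoxy itself or would also appear with a hydroxyl, a chlorine atom or an ethoxy group on the same carbon. They also leave open whether methoxy on the ring of the benzyl group of compound 2 would give a comparable step, or whether the step is tied to the phenyl of compound 1.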